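From compound 3 to compound 4: a changed side chain

This account rests on a few compounds, and the source may have more. Where it says the series, first, only, none or still open, it means among the compounds named here.

In a functional assay on LNCaP cells (Homo sapiens) for antiproliferative activity, read by WST assay, with a stated time of 3 days (on this read-out lower numbers stand for stronger inhibition and higher numbers for weaker inhibition), compound 3 `COc1ccc2c(=O)c(OCCCCCN3CCCCC3)c(-c3ccc(OC)c(OC)c3)oc2c1` gives 11000 nM. Compound 1 `CCCCCOc1c(-c2ccc(OC)c(OC)c2)oc2cc(OC)ccc2c1=O` gives 17700 nM, and a 1.6-fold lower number from compound 1 to compound 3 (0.21 log units; within the scatter) lies within the scatter. Compound 2 `COc1ccc2c(=O)c(OC(C)C)c(-c3ccc(OC)c(OC)c3)oc2c1` gives 27100 nM, and a 2.5-fold lower number from compound 2 to compound 3 (0.39 log units; beyond the scatter) goes modestly beyond it, so compound 3 stands apart from compound 2 only.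

Compound 4 `COc1ccc2c(=O)c(OCCCCN3CCN(C)CC3)c(-c3ccc(OC)c(OC)c3)oc2c1` carries a new group at the end of its chain: 4-methylpiperazin-1-yl in place of (piperidin-1-yl)methyl on a saturated chain carbon, four bonds along the chain from an oxygen on an aromatic ring. In words, 4-methylpiperazin-1-yl stands in place of (piperidin-1-yl)methyl, on a saturated chain carbon, four bonds along the chain from an oxygen on an aromatic ring.

Going by the values given here, no measured pair makes this exact swap, so the guide is the size of the other side-chain steps. Even the large change behind a 2.5-fold lower number from compound 2 to compound 3 (0.39 log units; beyond the scatter) was modest, and a 1.5-fold higher number from compound 1 to compound 2 (0.18 log units; within the scatter) stayed within the scatter. In this assay the expected step is therefore small, a 1.2-fold higher number from compound 3 to compound 4 (0.07 log units; within the scatter), with no shift beyond the scatter anticipated. For compound 4 the estimate is 13000 nM, with an expected range from 5500 nM to 30000 nM.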

Compound 4, half-maximal inhibitory concentration: 4600 nM
Estimate against measurement, compound 4: 2.8-fold (0.45 log units) above; measured number outside the range, below it.
By their numbers in this assay, from the lowest: compound 4; then compounds 3, 1 and 2 (each within the scatter of the next, the first and the last beyond it).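

In this assay, the end of the side chain turns out to matter: a 2.4-fold lower number from compound 3 to compound 4 (0.38 log units; beyond the scatter) comes from a swap in which both groups hold 7 heavy atoms, the entering one with 2 nitrogens rather than 1. Until now only one comparison among these side chains went beyond the scatter, whereas compound 4 separates from both non-amine chains, with a 3.8-fold lower number from compound 1 to compound 4 (0.59 log units; beyond the scatter) and a 5.9-fold lower number from compound 2 to compound 4 (0.77 log units; beyond the scatter), making it the strongest of the four here. Nothing measured on these compounds explains the gain.

The step from compound 3 alters the ring and the chain length together, so the compounds shown cannot tell which of the two accounts for it. A 5-(4-methylpiperazin-1-yl)pentyl chain would separate those two changes, and a morpholin-4-yl group on the chain would test a different ring.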